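NOTUM inhibition: methyl to isopropyl on the aryl ring

The compounds below may be only part of what the source reports. "The series", "measured", "known", "first", "only" and "open" are said of these compounds alone.

Measured compounds:
Compound 1, `O=C(O)c1c[nH]c(C(F)(F)F)c1`: > 100000 nM
Compound 2, `Cc1cccc(-n2c(C)cc(C(=O)O)c2C)c1`: 1500 nM

In an assay on cells for inhibition of Palmitoleoyl-protein carboxylesterase NOTUM variant C330S (Homo sapiens), read by fluorescence, with a stated time of 40 min (on this read-out higher numbers stand for weaker inhibition and lower numbers for stronger inhibition), compound 1 gives > 100000 nM, which is a limit of the assay and not a number, as the evidence the limit of > 100000 nM in this assay, at which 1 of the 2 values shown sits, records. Compound 2 gives 1500 nM in this assay; this is the only true number shown, so compound 2 has no measured neighbour against which to rank it.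

Compound 3, `Cc1cc(C(=O)O)c(C)n1-c1cccc(C(C)C)c1`, differs from compound 2 in one place: isopropyl in place of methyl on an aromatic carbon. Within the data shown here, no step between measured compounds is available for comparison. The step from compound 2 to compound 3 is expected to be small, toward stronger inhibition, at a 1.9-fold lower number from compound 2 to compound 3 (0.27 log units; within the scatter), but it may well fall within the scatter. Compound 3 is therefore estimated at 800 nM in this assay, with a range from 250 nM to 3000 nM.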

Compound 3, half-maximal inhibitory concentration: 360 nM
Compound 3: middle estimate off by 2.2-fold (0.35 log units), on the high side; measured number inside the range.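

Replacing methyl with isopropyl on an aromatic carbon, meta to a large group, gives a 4.2-fold lower number from compound 2 to compound 3 (0.62 log units; beyond the scatter) in this assay, so the larger alkyl group at this place goes with stronger inhibition. Among these compounds, compound 1 and compound 2 offered no step to read, and this first one, though modest, lies beyond the scatter. Nothing shown here gives a reason for this step.

As far as these compounds go, it remains open whether a longer chain, such as n-propyl, or a tert-butyl or cyclopropyl group at the same place would carry the change further, and whether a methoxy group or a chlorine atom would have a similar effect. A single step at one place also says nothing about how the other places on this six-membered aromatic ring respond.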